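The compounds below may be only part of what the source reports. "The series", "measured", "known", "first", "only" and "open" are said of these compounds alone.

Measured so far:
- compound 1 `COc1cc(C2Oc3cc([C@H]4Oc5cc(O)cc(O)c5C(=O)[C@@H]4O)ccc3OC2COC(=O)c2ccc(N)cc2)ccc1O`: 14300 nM
- compound 2 `COc1cc(C2Oc3cc([C@H]4Oc5cc(O)cc(O)c5C(=O)[C@@H]4O)ccc3OC2COC(=O)c2cc([N+](=O)[O-])cc([N+](=O)[O-])c2)ccc1O`: 14600 nM

In a functional assay on liver (Rattus norvegicus, strain Sprague-Dawley) for inhibition, with a stated time of 1 h (a lower number here means a stronger inhibitor, a higher number a weaker inhibitor), compound 2 gives 14600 nM, level with compound 1 within the scatter. Compound 3 `CCOC(=O)CC(=O)OCC1Oc2ccc([C@H]3Oc4cc(O)cc(O)c4C(=O)[C@@H]3O)cc2OC1c1ccc(O)c(OC)c1` is still unmeasured. It carries (ethoxycarbonyl)methyl in place of 3,5-dinitrophenyl on a carbonyl carbon.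

Among the measured compounds shown here, one measured step bears on this change, a 1.0-fold higher number from compound 1 to compound 2 (0.01 log units; within the scatter), made on the same carbonyl carbon. It lay within the scatter, even though the two groups exchanged there differ considerably. Both of those groups contain a ring, however, and the entering group has none, so the evidence is thin and the range is kept wide. No shift beyond the scatter is expected in this assay, and the expected size is a 1.0-fold lower number from compound 2 to compound 3 (0.02 log units; within the scatter). For compound 3 the estimated value is 14000 nM, with an expected range from 6000 nM to 32000 nM.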

Compound 3, half-maximal inhibitory concentration: 33400 nM
Estimate against measurement, compound 3: 2.4-fold (0.38 log units) below; the whole stated range lies below it.
By their numbers in this assay, from the lowest: compounds 1 and 2 (each within the scatter of the next); then compound 3.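

In this assay the carbonyl carbon is not indifferent to its substituent: (ethoxycarbonyl)methyl in place of 3,5-dinitrophenyl gives a 2.3-fold higher number from compound 2 to compound 3 (0.36 log units; beyond the scatter) and in place of 4-aminophenyl gives a 2.3-fold higher number from compound 1 to compound 3 (0.37 log units; beyond the scatter) and both steps are modest but beyond the scatter. The two groups with an aromatic ring stay level with each other, and only the group with no ring and fewer heavy atoms stands apart, so among these three compounds the higher number goes with the loss of the ring. No measurement at hand gives a reason for this shift.

Open, going by these compounds, is whether the missing ring or the ester in the entering group goes with the shift. An unsubstituted phenyl, a cyclohexyl ring, a plain ethyl chain or a carboxylic acid in place of the ethyl ester would help separate these two readings.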